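A few compounds are considered here, and "the series" means these few. Any claim that something is new, unique, unknown or untested is made for them only; others in the source may bear on it.

Compound 3 `CCOC(=O)C1=C(Nc2ccccc2)S/C(=C\c2cccnc2)C1=O` stands lowest of the three numbers measured in a functional assay on JAR cells (Homo sapiens) for inhibition, read by MTT assay, with a stated time of 72 h, tested at 10 uM; on this read-out higher numbers stand for more inhibition at the one concentration tested (going by the name of the read-out) and lower numbers for less inhibition: compound 3 gives 32.1%. Compound 1 `CCOC(=O)C1=C(Nc2ccccc2)S/C(=C\c2ccc(Br)c(O)c2)C1=O` gives 39.8%, and compound 2 `CCOC(=O)C1=C(Nc2ccccc2)S/C(=C\c2ccc[nH]2)C1=O` gives 49.2%. The step of a number 7.7 percentage points lower from compound 1 to compound 3 (within the scatter) stays within the scatter, whereas a number 17.1 percentage points lower from compound 2 to compound 3 (beyond the scatter) lies beyond it. Compound 4 `CCOC(=O)C1=C(Nc2ccccc2)S/C(=C\c2cc3ncccc3[nH]2)C1=O` differs from compound 3 in one place: a group of 9 heavy atoms (7 carbon, 2 nitrogen; one five-membered aromatic ring with 1 hetero atom, one six-membered aromatic ring with 1 hetero atom) in place of a group of 6 heavy atoms (5 carbon, 1 nitrogen; one six-membered aromatic ring with 1 hetero atom), on a double-bonded chain carbon bound to a double-bonded ring carbon. The entering group shares with the pyrrol-2-yl of compound 2 a five-membered aromatic ring carrying one hydrogen-bond donor, and that ring gave the highest of the three numbers. Going by these compounds, a moderate rise from compound 3 to compound 4 is therefore expected, a number 10.9 percentage points higher from compound 3 to compound 4 (beyond the scatter), though the entering group itself is untested. Compound 4 is estimated at 43%, between 27% and 60%.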

Compound 4, a percentage reported as inhibition, at one concentration (the size of the read-out at that concentration, not a potency): 74.8%
Compound 4: the middle estimate sits 31.8 percentage points below what was measured; measured number above the stated range.
By their numbers in this assay, from the lowest: compounds 3, 1 and 2 (each within the scatter of the next, the first and the last beyond it); then compound 4.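

Swapping the single ring for the group carrying one five-membered and one six-membered aromatic ring raises the number in this assay, with a number 42.7 percentage points higher from compound 3 to compound 4 (beyond the scatter) and a number 25.6 percentage points higher from compound 2 to compound 4 (beyond the scatter) and also a number 35 percentage points higher from compound 1 to compound 4 (beyond the scatter) in the same place. The single-ring groups alone differed far less, so this position can shift the read-out much further than they suggested. Nothing available explains the gain.

Still open, going by these compounds, is whether the gain needs the nitrogen of the six-membered ring, which an indol-2-yl group, with carbon only in that ring, would test.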